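Replacing the Ring Amine with an Open Dimethylamino Chain

The compounds below may be only part of what the source reports. "The series", "measured", "known", "first", "only" and "open" are said of these compounds alone.

Compound 1 `O=C1c2c[n+]([O-])c3ccccc3c2C(=O)c2c1c1ccccc1n2Cc1cn(C[C@@H](O)CO)nn1` gives 670 nM in a functional assay on MDA-MB-231 cells (Homo sapiens) for cytotoxicity, read by MTT assay, with a stated time of 72 h; on this read-out lower numbers stand for stronger inhibition and higher numbers for weaker inhibition.
Compound 2 `O=C1c2c[n+]([O-])c3ccccc3c2C(=O)c2c1c1ccccc1n2CCCCN1CCCCC1` gives 610 nM.
Compound 3 `O=C1c2c[n+]([O-])c3ccccc3c2C(=O)c2c1c1ccccc1n2CCCCN1CCNCC1` gives 3310 nM.

Compound 3 shows the highest number of the three and is the weakest inhibitor here, since both a 4.9-fold higher number from compound 1 to compound 3 (0.69 log units; beyond the scatter) and a 5.4-fold higher number from compound 2 to compound 3 (0.73 log units; beyond the scatter) lie beyond the scatter. Compound 4 `CN(C)CCCCCn1c2c(c3ccccc31)C(=O)c1c[n+]([O-])c3ccccc3c1C2=O` differs from compound 3 by (dimethylamino)methyl in place of piperazin-1-yl on a saturated chain carbon, four bonds along the chain from an aromatic nitrogen. The step that bears on this is a 5.4-fold higher number from compound 2 to compound 3 (0.73 log units; beyond the scatter), where piperazin-1-yl in place of piperidin-1-yl gave a clearly higher number. The present change removes the piperazin-1-yl for an open chain amine that resembles piperidin-1-yl more than piperazin-1-yl. The expected step is therefore a lower number, a 4.1-fold lower number from compound 3 to compound 4 (0.62 log units; beyond the scatter). Compound 4 is estimated at 800 nM, ranging from 300 nM to 2500 nM.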

Compound 4, half-maximal inhibitory concentration: 240 nM
Estimate against measurement, compound 4: 3.3-fold (0.52 log units) above; measured number below the stated range.
By their numbers in this assay, from the lowest: compound 4; then compounds 2 and 1 (each within the scatter of the next); then compound 3.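

In this assay, among these compounds, the open dimethylamino chain does more than recover what the piperazin-1-yl ring lost, giving the largest step so far (a 14-fold lower number from compound 3 to compound 4 (1.14 log units; beyond the scatter)). It also goes beyond the piperidin-1-yl ring (a 2.5-fold lower number from compound 2 to compound 4 (0.41 log units; beyond the scatter)) and the dihydroxypropyl triazole (a 2.8-fold lower number from compound 1 to compound 4 (0.45 log units; beyond the scatter)), so among these four compounds the lowest number belongs to the open chain. No evidence on the cause is available here. Still open, going by these compounds, is how a diethylamino or pyrrolidin-1-yl end would compare on the same chain, and whether a shorter or longer chain carrying dimethylamino would keep this result.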